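A carbonyl enters at the amine nitrogen

The compounds below may be only part of what the source reports. "The series", "measured", "known", "first", "only" and "open" are said of these compounds alone.

Of the compounds shown here, three sharing one core have been read in a functional assay on OVCAR-3 cells (Homo sapiens) for antiproliferative activity, read by MTT assay, with a stated time of 24 h; a lower number here means a stronger inhibitor, a higher number a weaker inhibitor. Compound 1 (`Cc1cccc(NNC(=O)c2cccc(NS(=O)(=O)c3cnc(O)nc3O)c2)c1`) gives > 20000 nM, which is a limit of the assay and not a number. Compound 2 (`O=C(NNc1ccccc1F)c1cccc(NS(=O)(=O)c2cnc(O)nc2O)c1`) gives 17000 nM, and compound 3 (`O=C(NNc1ccccc1F)c1ccccc1NS(=O)(=O)c1cnc(O)nc1O`) gives 9570 nM. These last two values lie within the scatter of each other, so compound 3 stands level with compound 2 on the numbers available.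

Compound 4 (`O=C(NNC(=O)c1ccccc1NS(=O)(=O)c1cnc(O)nc1O)c1ccccc1F`) follows from compound 3 with (2-fluorophenyl)carbonyl in place of 2-fluorophenyl on an amine nitrogen. Going by the values given here, the one measured step is an at least 1.1-fold lower number from compound 1 to compound 2 (0.07 log units; that floor lies within the scatter), with 2-fluorophenyl in place of 3-methylphenyl on an amine nitrogen. It acts at the same kind of place, but it brings in no carbonyl and its size is only a floor, so it offers weak guidance. Among the compounds with values here, no measured step adds a carbonyl here, and the estimate therefore starts from compound 3 at 9570 nM. No change beyond the scatter is expected in this assay, and the expected step is a 1.1-fold higher number from compound 3 to compound 4 (0.06 log units; within the scatter). Compound 4 is estimated at 11000 nM, with an expected range of 4000 nM to 25000 nM.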

Compound 4, half-maximal inhibitory concentration: 15300 nM
The estimate for compound 4 lay 1.4-fold (0.14 log units) below the measured number; measured number inside the range.
By their numbers in this assay, from the lowest: compounds 3, 4 and 2 (each within the scatter of the next). At a limit, above all of these: compound 1.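

Adding the carbonyl at the amine nitrogen whose other neighbour is the amide-type nitrogen gives, in this assay, a 1.6-fold higher number from compound 3 to compound 4 (0.20 log units; within the scatter), so (2-fluorophenyl)carbonyl takes the place of 2-fluorophenyl with no readable change in antiproliferative activity. Unlike the earlier step at this nitrogen, which rests on a limit at one end, this step has a measured number at both ends, and it shows that the group entering here can carry a hydrogen-bond acceptor and a double bond outside aromatic rings while the reading stays within the scatter. The measured numbers of this small set nevertheless all lie in a narrow band not far from the ceiling of the assay, which restricts how much any step here can show: the limit of > 20000 nM in this assay, at which 1 of the 4 values shown sits.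

Going by these compounds, it remains open whether any group on this nitrogen, such as an amine, a carboxylic acid or a longer alkyl chain in place of the 2-fluorophenyl ring, would move the reading beyond the scatter. Also open, on these data alone, is whether the same carbonyl would read alike on the core of compound 2.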